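Compound 3: Same Atoms, Joined Differently

The source may hold more compounds than are shown below. What is called first, only, known or untested is meant among the compounds shown, and "the series" means these compounds.

Compound 1 `CCCCCCCCN(C)C(=O)Cn1cc(Cc2cnc(OC)nc2)c(=O)nc1SCc1ccc(F)cc1` gives 39% in a functional assay on a cell-free system (plasma) for inhibition of platelet-activating factor acetylhydrolase (Homo sapiens), tested at 100 nM; on this read-out lower numbers stand for less inhibition and higher numbers for more inhibition at the one concentration tested (going by the name of the read-out).
Compound 2 `CCCCCCCCN(C)C(=O)Cn1cc(Cc2cnc(OCC)nc2)c(=O)nc1SCc1ccc(F)cc1` gives 23% in this assay.

Compound 2 stands lowest of the two numbers in this assay; compound 1 is its nearest neighbour, and the two are separated by a number 16 percentage points lower from compound 1 to compound 2 (beyond the scatter). Compound 3 `CCCCCCCCN(C)C(=O)Cn1cc(Cc2cnc(=O)n(CC)c2)c(=O)nc1SCc1ccc(F)cc1` has the same atoms as compound 2, joined differently: a group of 9 heavy atoms (6 carbon, 2 nitrogen, 1 oxygen; one six-membered aromatic ring with 2 hetero atoms) in place of a group of 9 heavy atoms (6 carbon, 2 nitrogen, 1 oxygen; one six-membered aromatic ring with 2 hetero atoms), on a saturated chain carbon bound to an aromatic carbon. Within the data shown here, no measured step matches this change. Among the measured compounds shown here, the only step at hand, a number 16 percentage points lower from compound 1 to compound 2 (beyond the scatter), concerns a methyl added on the chain bound to the ring oxygen, not a rearrangement of the ring itself, and it was modest. Lacking a comparable step, compound 3 is expected to stay close to compound 2, and the step of a number 1 percentage points lower from compound 2 to compound 3 (within the scatter) is expected to lie within the scatter, with a lower number not ruled out. Compound 3 is therefore estimated at 22%, within 5% to 45%.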

Compound 3, a percentage reported as inhibition, at one concentration (the size of the read-out at that concentration, not a potency): 48%
Beside the measured number, compound 3's estimate is 26 percentage points below it; measured number outside the range, above it.
By their numbers in this assay, from the lowest: compound 2; then compounds 1 and 3 (each within the scatter of the next).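

In this assay, among these compounds, the earlier compounds showed only what a methyl added to the chain on the ring oxygen does. Compound 3 shows that this position also answers to how the same atoms are joined: replacing the 2-ethoxypyrimidin-5-yl group with an isomeric ring group carrying one double bond outside aromatic rings gives a number 25 percentage points higher from compound 2 to compound 3 (beyond the scatter). The rejoined group, though larger than the group it replaces in compound 1, gives a number 9 percentage points higher from compound 1 to compound 3 (within the scatter), so no order can be set between those two, and nothing at hand explains the difference between the two isomers.

The compounds shown leave open how the rejoined ring would read with a propyl chain in place of its ethyl. They also leave open whether an amine on that ring would keep the number seen for compound 3.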